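The compounds below may be only part of what the source reports. "The series", "measured", "known", "first", "only" and "open" are said of these compounds alone.

Measured compounds, with values from a functional assay on B16 cells (Mus musculus) for cytotoxicity, read by MTT assay, with a stated time of 48 h; a higher number here means a weaker inhibitor, a lower number a stronger inhibitor:

Compound 1 `CCOC(=O)Cn1cc(-c2ccc3ccccc3c2)nn1`: compound 1 reaches only the limit > 100000 nM and gives no number.
Compound 2 `CC1(C)OCC(Cn2cc(-c3ccc4ccccc4c3)nn2)O1`: compound 2 gives 6600 nM.
Compound 3 `CC1(C)OCC(Cn2cc(-c3ccc([N+](=O)[O-])cc3)nn2)O1`: compound 3 reaches only the limit > 100000 nM and gives no number.

Compound 2 and compound 1 differ in one place, (ethoxycarbonyl in place of 2,2-dimethyl-1,3-dioxolan-4-yl on a saturated chain carbon bound to an aromatic nitrogen). This change gives an at least 15-fold higher number from compound 2 to compound 1 (1.18 log units; beyond the scatter). The size of that step cannot be fixed more closely, since the value of compound 1 is a limit; the pattern among the values is summarised by the limit of > 100000 nM in this assay, at which 2 of the 3 values shown sit.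

Compound 3 carries the same 2,2-dimethyl-1,3-dioxolan-4-yl group as compound 2, but the difference between the two cores is not broken down here.

Compound 4 `CCOC(=O)Cn1cc(-c2ccc([N+](=O)[O-])cc2)nn1` is not yet measured in this assay. It stands to compound 3 as compound 1 stands to compound 2: ethoxycarbonyl in place of 2,2-dimethyl-1,3-dioxolan-4-yl on a saturated chain carbon bound to an aromatic nitrogen. The place is given in the same words for both pairs, so this is the same kind of change. In compound 2 the change led to an at least 15-fold higher number from compound 2 to compound 1 (1.18 log units; beyond the scatter), and compound 3 already sits at the limit > 100000 nM. The expectation for compound 4 in this assay is therefore a step no smaller than a step that the limit leaves unreadable from compound 3 to compound 4, resting on the step from compound 2 to compound 1 and on the limit shown for compound 3. Compound 4 is estimated at 250000 nM, most likely reported only as a limit rather than a number, with an expected range from 100000 nM to 1000000 nM.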

Compound 4, half-maximal inhibitory concentration: > 100000 nM
Compound 4: only a limit was reported; the forecaster's own chance of this, stated with the estimate: 90%; the middle value is on the limit's open side.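

In this assay compound 4 gives > 100000 nM, which is a limit and not a number. For the compounds shown here, compound 3 also stands only at a limit, so no step from compound 3 to compound 4 can be read. The values shown gather at one limit: the limit of > 100000 nM in this assay, at which 3 of the 4 values shown sit.

Still open, from the compounds shown here alone, is whether ethoxycarbonyl in place of 2,2-dimethyl-1,3-dioxolan-4-yl changes anything on the core of compound 3, as it does on the core of compound 2.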